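Swapping a chlorophenyl for a dimethylphenyl on one core

The source may report more compounds than this note shows. Statements on the series, on what has been measured and on what is new or still open speak of the compounds shown alone.

Compound 1 `COc1cc(-c2cc3nccc(-c4c[nH]c5ccccc45)n3n2)cc(OC)c1OC` gives > 10000 nM in a functional assay on HeLa cells (Homo sapiens) for inhibition, read by CCK-8 assay, with a stated time of 48 h (on this read-out higher numbers stand for weaker inhibition and lower numbers for stronger inhibition), and this is a limit of the assay, not a number. In this assay, compound 2 `COc1cc(-c2ccnc3cc(-c4c[nH]c5ccccc45)nn23)cc(OC)c1OC` gives 195 nM. Compound 3 `COc1cc(-c2ccnc3cc(-c4ccc(Cl)cc4)nn23)cc(OC)c1OC` gives 1490 nM, the higher of the two actual numbers, which makes it the weaker inhibitor of that pair.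

Compound 4 `COc1cc(-c2ccnc3cc(-c4ccc(C)c(C)c4)nn23)cc(OC)c1OC` keeps the core of compound 3 and has 3,4-dimethylphenyl in place of 4-chlorophenyl on an aromatic carbon. Among the measured compounds shown here, only one measured step bears on this place, a 7.6-fold higher number from compound 2 to compound 3 (0.88 log units; beyond the scatter), where 4-chlorophenyl replaced 1H-indol-3-yl. That step lies beyond the scatter, but it left the indole behind, whereas here each group is one six-membered aromatic ring of carbon only. For the measured compounds named here, no measured step yet compares two such groups, so no clear shift is expected in this assay, and the direction stays open. The expected change is small, a 1.0-fold higher number from compound 3 to compound 4 (0.00 log units; within the scatter), within the scatter. For compound 4 the estimated value is 1500 nM, with an expected range from 400 nM to 5000 nM.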

Compound 4, half-maximal inhibitory concentration: 241 nM
Estimate against measurement, compound 4: 6.2-fold (0.79 log units) above; the whole stated range lies above it.
By their numbers in this assay, from the lowest: compounds 2 and 4 (each within the scatter of the next); then compound 3. At a limit, above all of these: compound 1.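

In this assay, among the compounds shown here, this is the first comparison at this place between two groups that each have one six-membered aromatic ring of carbon only, and a 6.2-fold lower number from compound 3 to compound 4 (0.79 log units; beyond the scatter) shows that the groups on that ring matter, a difference beyond the scatter. For the compounds shown here, the indole is also not the only group that gives a low number here: a 1.2-fold higher number from compound 2 to compound 4 (0.09 log units; within the scatter) is within the scatter, so 3,4-dimethylphenyl and 1H-indol-3-yl cannot be told apart in this assay. Nothing shown gives a reason for the gap between 4-chlorophenyl and 3,4-dimethylphenyl.

Going by these compounds, whether a single methyl group, as in 4-methylphenyl or 3-methylphenyl, would be enough remains open. So does the outcome with an amine, a carboxylic acid or a longer chain on this ring.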